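Swapping quinolin-6-yl for naphthalen-1-yl in compound 1

This account rests on a few compounds, and the source may have more. Where it says the series, first, only, none or still open, it means among the compounds named here.

In a functional assay on A549 cells (Homo sapiens) for antiproliferative activity, with a stated time of 5 days (on this read-out higher numbers stand for weaker inhibition and lower numbers for stronger inhibition), compound 1 `O=C1C=CC2(C=C1)OCC(=O)N2c1nc(-c2ccc3ncccc3c2)nn1-c1ccccc1` gives 170 nM, and compound 2 `O=C1C=CC2(C=C1)OCC(=O)N2c1nc(-c2ccc3ccccc3c2)nn1-c1ccc2ccccc2c1` gives 250 nM. For the measured compounds named here, these two numbers lie within the usual scatter of repeated measurements, so compound 1 cannot be separated from the only other measured compound. The next compound to be tested is compound 3 `O=C1C=CC2(C=C1)OCC(=O)N2c1nc(-c2cccc3ccccc23)nn1-c1ccccc1`, which carries naphthalen-1-yl in place of quinolin-6-yl on an aromatic carbon of the five-membered ring with three nitrogens. The swap is summed up as naphthalen-1-yl in place of quinolin-6-yl on an aromatic carbon. Going by the values given here, no two measured compounds differ in just one place, so no measured step shows what this swap does in this assay. A small move towards weaker inhibition is expected, a 1.6-fold higher number from compound 1 to compound 3 (0.22 log units; within the scatter), and it may well stay within the scatter. Compound 3 is estimated at 280 nM, with an expected range from 90 nM to 850 nM.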

Compound 3, half-maximal inhibitory concentration: 80 nM
Estimate against measurement, compound 3: 3.5-fold (0.54 log units) above, and the stated range ends above it.
By their numbers in this assay, from the lowest: compound 3; then compounds 1 and 2 (each within the scatter of the next).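

In this assay, for the compounds shown here, this is the first step measured at this aromatic carbon, and it gives a 2.1-fold lower number from compound 1 to compound 3 (0.33 log units; beyond the scatter), a modest change that lies just beyond the scatter. Quinolin-6-yl is therefore not required here, and an all-carbon naphthalen-1-yl serves at least as well when phenyl is the other group on the five-membered ring. The swap removes the ring nitrogen and also moves the point of attachment, and no measurement at hand explains the lower number.

The compounds shown leave open whether the ring nitrogen or the attachment point accounts for the step, which quinolin-5-yl on this carbon could help to separate. Also open, from the compounds shown here alone, is how a single ring such as pyridin-3-yl, or a chain ending in an amine, would behave at this carbon.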